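One Methyl Step, Measured Once, Then Expected Again

A few compounds are considered here, and "the series" means these few. Any claim that something is new, unique, unknown or untested is made for them only; others in the source may bear on it.

Three compounds have been measured in a functional assay on HT-29 cells (Homo sapiens) for inhibition, read by MTT assay, with a stated time of 72 h; on this read-out lower numbers stand for stronger inhibition and higher numbers for weaker inhibition:
compound 1, `COc1cc2c(Oc3ccc(NC(=O)c4nn(-c5ccccc5C(F)(F)F)c(=O)cc4C)cc3F)ccnc2cc1OCCCN1CCCCC1`, 170 nM;
compound 2, `COc1cc2c(Oc3ccc(NC(=O)c4nn(-c5ccccc5C(F)(F)F)c(=O)cc4C)cc3F)ccnc2cc1OCCCN1CCC(C)CC1`, 180 nM;
compound 3, `COc1cc2c(Oc3ccc(NC(=O)c4nn(-c5ccccc5OC(F)(F)F)c(=O)cc4C)cc3F)ccnc2cc1OCCCN1CCCCC1`, 190 nM.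

Compound 2 differs from compound 1 by methyl in place of hydrogen on a saturated ring carbon, and this change made a step of a 1.1-fold higher number from compound 1 to compound 2 (0.02 log units; within the scatter). The core of compound 3 differs from that of compound 1 by trifluoromethoxy in place of trifluoromethyl on an aromatic carbon, which made a step of a 1.1-fold higher number from compound 1 to compound 3 (0.05 log units; within the scatter). All three numbers thus sit within the scatter of one another, and no order among them can be read.

The unmeasured compound 4, `COc1cc2c(Oc3ccc(NC(=O)c4nn(-c5ccccc5OC(F)(F)F)c(=O)cc4C)cc3F)ccnc2cc1OCCCN1CCC(C)CC1`, differs from compound 3 by methyl in place of hydrogen on a saturated ring carbon. This is the same change that leads from compound 1 to compound 2, at the same place. For compound 4 the step is expected to be a 1.1-fold higher number from compound 3 to compound 4 (0.02 log units; within the scatter), beside the earlier one of a 1.1-fold higher number from compound 1 to compound 2 (0.02 log units; within the scatter), because that earlier step a 1.1-fold higher number from compound 1 to compound 2 (0.02 log units; within the scatter) stayed within the scatter. Compound 4 is therefore expected to give about 200 nM in this assay, estimated to lie between 100 nM and 400 nM.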

Compound 4, half-maximal inhibitory concentration: 250 nM
The estimate for compound 4 lay 1.3-fold (0.10 log units) below the measured number, within the range that was stated.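

In this assay the change from piperidin-1-yl to 4-methylpiperidin-1-yl on the core of compound 3 made a step of a 1.3-fold higher number from compound 3 to compound 4 (0.12 log units; within the scatter), and it carried over from the core of compound 1 with no difference that can be read: the same change on two cores in this assay, a 1.1-fold higher number (0.02 log units; within the scatter) from compound 1 to compound 2 and a 1.3-fold higher number (0.12 log units; within the scatter) from compound 3 to compound 4, 1.2-fold (0.09 log units) apart, within the scatter of two such steps

Trifluoromethoxy in place of trifluoromethyl, read here with the methyl present, made a step of a 1.4-fold higher number from compound 2 to compound 4 (0.14 log units; within the scatter), and this change also carried over with no readable difference: the same change on two cores in this assay, a 1.1-fold higher number (0.05 log units; within the scatter) from compound 1 to compound 3 and a 1.4-fold higher number (0.14 log units; within the scatter) from compound 2 to compound 4, 1.2-fold (0.09 log units) apart, within the scatter of two such steps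

Within the data shown here, every one of these steps lies within the scatter, so the four compounds show only that neither change moved the number measurably on these two cores; they do not show that a step of real size would carry over from one core to another, nor that the two changes add up.

The compounds shown leave open whether a morpholine or a piperazine in place of the piperidine, or a carboxylic acid on that ring, would move the number beyond the scatter. They also leave open whether a shorter or longer chain to the ring would do so.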